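Methyl for Phenyl on the Ring Amide Nitrogen

This account rests on a few compounds, and the source may have more. Where it says the series, first, only, none or still open, it means among the compounds named here.

Compound 1 `CN1C(=O)C2ON=C(c3cn(-c4ccccc4)nc3-c3ccccc3)C2C1=O`: 1.17%
Compound 2 `CN1C(=O)C2ON=C(c3cn(-c4ccccc4)nc3-c3ccc(Br)cc3)C2C1=O`: 9.81%
Compound 3 `CCOc1ccc(-c2nn(-c3ccccc3)cc2C2=NOC3C(=O)N(c4ccccc4)C(=O)C23)cc1`: 12.2%

In a functional assay on the whole organism (Abdomen, strain Swiss albino) with Mus musculus as the target, with stated times of 10 min and 5 min, at a dose of 15 mg/kg by the oral route (on this read-out lower numbers stand for a weaker effect and higher numbers for a stronger effect at the one dose given), compound 3 gives the highest of the three numbers; its gap to compound 2 is within the scatter, while compound 1 lies beyond it. Compound 4 `CCOc1ccc(-c2nn(-c3ccccc3)cc2C2=NOC3C(=O)N(C)C(=O)C23)cc1` differs from compound 3 by methyl in place of phenyl on an amide-type nitrogen in a ring. Among the measured compounds shown here, no measured pair differs only at this place: the one measured step, a number 8.6 percentage points higher from compound 1 to compound 2 (within the scatter), concerns bromo on an aromatic carbon and does not bear on it. Compound 1 and compound 2 already carry methyl on that nitrogen and sit lower than compound 3, but they differ from it elsewhere too. For compound 4 the expected step is a number 4.2 percentage points lower from compound 3 to compound 4 (within the scatter), not beyond the scatter. The estimate for compound 4 is 8%, between 0% and 20%.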

Compound 4, a percentage reported as activity, at one dose (the size of the read-out at that dose, not a potency): 22.8%
Compound 4: middle estimate off by 14.8 percentage points, on the low side; measured number outside the range, above it.
By their numbers in this assay, from the lowest: compounds 1, 2 and 3 (each within the scatter of the next, the first and the last beyond it); then compound 4.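

In this assay, among the compounds shown here, the first comparison at this ring nitrogen gives a number 10.6 percentage points higher from compound 3 to compound 4 (beyond the scatter), showing that with ethoxy held in place, methyl in place of phenyl raises the number. With methyl on that nitrogen, the ethoxy group also matters on the aromatic carbon, with a number 13 percentage points higher from compound 2 to compound 4 (beyond the scatter) for ethoxy in place of bromo and a number 21.6 percentage points higher from compound 1 to compound 4 (beyond the scatter) for ethoxy in place of hydrogen. No measurement here explains these steps. From the compounds shown here alone, how an ethyl or benzyl group on that nitrogen would compare remains open, as does the effect of an amine or a carboxylic acid in place of ethoxy.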